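From Nitro to Amino: Compound 4 Awaits Its Measurement

A few compounds are considered here, and "the series" means these few. Any claim that something is new, unique, unknown or untested is made for them only; others in the source may bear on it.

Of the compounds shown here, three have so far been tested in a functional assay on A2780 cells (Homo sapiens) for inhibition, with a stated time of 72 h; a lower number here means a stronger inhibitor, a higher number a weaker inhibitor. In this test, compound 1 `CC1(C)CCNc2ccc(NC(=O)Nc3ccc([N+](=O)[O-])cc3)cc21` gives 6900 nM, compound 2 `CC1(C)CCNc2ccc(NC(=S)Nc3ccc([N+](=O)[O-])cc3)cc21` gives 7100 nM, and compound 3 `CN1c2ccc(NC(=O)Nc3ccc([N+](=O)[O-])cc3)cc2C(C)(C)C(=O)C1(C)C` gives 3800 nM. Going by the values given here, compound 3 therefore stands level with the other two, since its gaps to both lie within the usual scatter of repeated measurements, and the numbers set no compound of the three apart.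

The next compound is compound 4 `CN1c2ccc(NC(=O)Nc3ccc(N)cc3)cc2C(C)(C)C(=O)C1(C)C`, which keeps the core of compound 3 and carries amino in place of nitro on an aromatic carbon, the swap from 4-nitrophenyl to 4-aminophenyl. The change is counted as follows: amino in place of nitro on an aromatic carbon. Among the compounds with values here, none of the three tested compounds carries amino at this place, and no step between tested compounds is available as a guide, so the data offer only a weak basis for a prediction. The closeness of compound 1 at 6900 nM and compound 3 at 3800 nM gives no reason to predict a large move in this assay. The expected step is a 1.3-fold higher number from compound 3 to compound 4 (0.12 log units; within the scatter), which is no change beyond the scatter, though the uncertainty is wide in both directions. For compound 4 the estimated value is 5000 nM, with an expected range from 1500 nM to 17000 nM.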

Compound 4, half-maximal inhibitory concentration: 7700 nM
The estimate for compound 4 lay 1.5-fold (0.19 log units) below the measured number; the range from low to high includes it.
By their numbers in this assay, from the lowest: compounds 3, 1, 2 and 4 (each within the scatter of the next, the first and the last beyond it).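

Going by these compounds alone, with the core of compound 3 held fixed, amino in place of nitro on an aromatic carbon brings a 2.0-fold higher number from compound 3 to compound 4 (0.31 log units; beyond the scatter) in this assay and this is the first step between compounds differing in one place, so this position can now be judged directly. The earlier compounds shown here could say nothing about this place, whereas the swap from 4-nitrophenyl to 4-aminophenyl now moves the number modestly past the scatter, towards a weaker inhibitor, though this rests on a single pair. No supporting measurement accompanies the step, and what lies behind it stays unexplained.

From the compounds shown here alone, only nitro and amino have stood at this place on this core, so it remains open whether the step reflects the loss of nitro or the arrival of amino, and a carboxylic acid, a methoxy group or a plain hydrogen on the same carbon could help separate the two. Also unsettled is whether the same swap on the core of compound 1 would move the number in the same direction and by a similar amount.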